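A Phenylethenyl in Place of a Dichlorophenyl

This account rests on a few compounds, and the source may have more. Where it says the series, first, only, none or still open, it means among the compounds named here.

Compound 1, `CC(=O)N1N=C(c2ccco2)CC1c1ccc(Cl)cc1`: 57400 nM
Compound 2, `O=CCN1N=C(c2ccc3ccccc3c2)CC1c1cccc(Cl)c1Cl`: 12500 nM

Both compounds were tested in a functional assay on HEp-2 cells (Homo sapiens) for cytotoxicity, read by sulforhodamine B assay, with a stated time of 48 h; a lower number here means a stronger inhibitor, a higher number a weaker inhibitor. Compound 2 gives the lower of the two numbers, and compound 1 gives a higher one; the gap between them lies beyond the usual scatter of this assay. Compound 3, `O=CCN1N=C(c2ccc3ccccc3c2)CC1/C=C/c1ccccc1`, has not yet been measured. It differs from compound 2 in one place: 2-phenylethenyl in place of 2,3-dichlorophenyl on a saturated ring carbon. Among the compounds with values here, no measured pair of compounds shows this single change, so its size is unknown, and compound 1 and compound 2 differ from each other in several places at once, which gives no guide here. The expected step from compound 2 to compound 3 is a 1.2-fold higher number from compound 2 to compound 3 (0.08 log units; within the scatter), which is estimated to stay within the scatter. In this assay compound 3 is expected to give 15000 nM, with a range from 4000 nM to 55000 nM.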

Compound 3, half-maximal inhibitory concentration: 20100 nM
For compound 3 the middle estimate is 1.3-fold (0.13 log units) below the measured one; the range from low to high includes it.
By their numbers in this assay, from the lowest: compounds 2 and 3 (each within the scatter of the next); then compound 1.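

Within the data shown here, compound 2 and compound 3 give the first direct reading of a change at this saturated ring carbon. In this assay the swap of 2,3-dichlorophenyl for 2-phenylethenyl amounts to a 1.6-fold higher number from compound 2 to compound 3 (0.21 log units; within the scatter). So this position can lose both chlorine atoms and take a double bond outside the aromatic ring with no change that stands clear of repeat-measurement noise, and nothing available explains why the two groups read alike.

On these data alone, both groups carry one six-membered aromatic ring of carbon only, so it remains open whether an amine, a carboxylic acid or a longer chain ending in a phenyl ring at this carbon would move the number beyond the scatter. Also open, as far as these compounds go, is whether the same swap would read alike on the core of compound 1.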